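The compounds below may be only part of what the source reports. "The series", "measured", "known", "first", "only" and "open" are said of these compounds alone.

In a toxicity assay on microsomes from liver (Homo sapiens) for metabolic stability, read by LC-MS, using NADPH, tested at 1 uM (a higher number here means faster removal of the compound, a lower number slower removal), compound 1 (`C[C@@H]1CN(c2sc(CN(C)C)nc2-c2nc3ccccc3[nH]2)CCN1C(=O)Cn1cnc2cccnc21`) gives 44 mL.min-1.g-1 and compound 2 (`C[C@@H]1CN(c2sc(C(F)(F)F)nc2-c2nc3ccccc3[nH]2)CCN1C(=O)Cn1cnc2cccnc21`) gives 89 mL.min-1.g-1. Compound 3 (`CCOc1ncc(-c2nc(C(F)(F)F)sc2N2CCN(C(=O)Cn3cnc4ccccc43)[C@H](C)C2)cn1`) stands highest of the three, at 662 mL.min-1.g-1. Compound 4 (`CCOc1ncc(-c2nc(C(F)(F)F)sc2N2CCN(C(=O)Cn3nccc3C)[C@H](C)C2)cn1`) departs from it at one place, on a saturated chain carbon bound to a carbonyl carbon: 5-methyl-1H-pyrazol-1-yl in place of 1H-benzimidazol-1-yl on a saturated chain carbon bound to a carbonyl carbon. Among the compounds with values here, only one single-place step has been measured, a 2.0-fold higher number from compound 1 to compound 2 (0.31 log units; beyond the scatter), and it is modest and lies at a different place, so it offers a scale and no direct precedent. A step of similar size in this assay is therefore expected, tentatively downward, as the data do not settle the direction. The expected change is a 2.2-fold lower number from compound 3 to compound 4 (0.34 log units; beyond the scatter). Compound 4 is estimated at 300 mL.min-1.g-1, with an expected range of 110 mL.min-1.g-1 to 750 mL.min-1.g-1.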

Compound 4, intrinsic clearance in microsomes: 65 mL.min-1.g-1
The estimate for compound 4 lay 4.6-fold (0.66 log units) above the measured number; the measured number lies below the stated range.
By their numbers in this assay, from the lowest: compounds 1, 4 and 2 (each within the scatter of the next, the first and the last beyond it); then compound 3.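

Within the data shown here, the group on a saturated chain carbon bound to a carbonyl carbon matters far more in this assay than the only earlier step suggested: a 10-fold lower number from compound 3 to compound 4 (1.01 log units; beyond the scatter) is large, while a 2.0-fold higher number from compound 1 to compound 2 (0.31 log units; beyond the scatter) at another place was modest. The change removes the six-membered aromatic ring of carbon only and leaves the counts of hydrogen-bond donors and acceptors as they were. Nothing at hand gives a reason for the step.

Going by these compounds, whether the loss of that ring or the added methyl carries the step remains open. So does how an amine or a carboxylic acid at this place would behave.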